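The source may report more compounds than this note shows. Statements on the series, on what has been measured and on what is new or still open speak of the compounds shown alone.

Measured so far in a functional assay on FM3A cells (Mus musculus), with a stated time of 2 days; a lower number here means a stronger inhibitor, a higher number a weaker inhibitor:
- compound 1 `O=C1C=CCO[C@@H]1n1ccc(O)nc1=O` gives 121000 nM
- compound 2 `O=C1C=CCO[C@@H]1n1cc(C(F)(F)F)c(O)nc1=O` gives 46000 nM

Compound 2 at 46000 nM holds the lower of the two numbers. Compound 3 `Cc1cn([C@H]2OCC=CC2=O)c(=O)nc1O` carries methyl in place of trifluoromethyl on an aromatic carbon, a change counted as methyl in place of trifluoromethyl on an aromatic carbon and not yet measured. Within the data shown here, the one measured step bearing on it is a 2.6-fold lower number from compound 1 to compound 2 (0.42 log units; beyond the scatter) with trifluoromethyl in place of hydrogen. Methyl has no measured precedent in this series, so a modest step to a higher number in this assay is expected, of about that size or smaller. Compound 3 is estimated at 85000 nM with an expected range of 35000 nM to 200000 nM for now. The expected move is a 1.8-fold higher number from compound 2 to compound 3 (0.27 log units; within the scatter) as an estimate only.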

Compound 3, half-maximal inhibitory concentration: 77000 nM
Compound 3: the middle estimate sits 1.1-fold (0.04 log units) above what was measured; the range from low to high includes it.
By their numbers in this assay, from the lowest: compounds 2, 3 and 1 (each within the scatter of the next, the first and the last beyond it).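

In this assay, methyl and trifluoromethyl on this aromatic carbon cannot be told apart (a step of a 1.7-fold higher number from compound 2 to compound 3 (0.22 log units; within the scatter)). Methyl and hydrogen at the same place also stay within the scatter of each other (a step of a 1.6-fold lower number from compound 1 to compound 3 (0.20 log units; within the scatter)), so methyl does not separate from either neighbour, and only the pair of hydrogen and trifluoromethyl lies beyond the scatter. Nothing at hand offers an explanation for this result.
Open, on these data alone, is how a halogen such as chlorine or bromine, or a longer chain such as ethyl, would read at this carbon. Also open, as far as these compounds go, is whether an amine or a carboxylic acid there would move the number beyond the scatter.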